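Dimethylamino to Fluoro: Expected Cytotoxicity of Compound 4

The compounds below may be only part of what the source reports. "The series", "measured", "known", "first", "only" and "open" are said of these compounds alone.

Compound 1 `COc1ccc(/C=N/NC(=O)c2ccc(C)cc2O)cc1`: 723000 nM
Compound 2 `Cc1ccc(C(=O)N/N=C/c2ccccc2)c(O)c1`: 578000 nM
Compound 3 `Cc1ccc(C(=O)N/N=C/c2ccc(N(C)C)cc2)c(O)c1`: 732000 nM

In an ADME assay on cells (Mus musculus, strain BALB/C) for cytotoxicity, read by MTT assay, with a stated time of 24 h (a higher number here means that more compound is tolerated, a lower number that less compound is tolerated), compound 3 holds the highest of the three numbers, yet it sits within the scatter of both others: a 1.0-fold higher number from compound 1 to compound 3 (0.01 log units; within the scatter) and a 1.3-fold higher number from compound 2 to compound 3 (0.10 log units; within the scatter). Compound 4 `Cc1ccc(C(=O)N/N=C/c2ccc(F)cc2)c(O)c1` differs from compound 3 by fluoro in place of dimethylamino on an aromatic carbon. For the measured compounds named here, the steps that bear on this change are the earlier exchanges on an aromatic carbon: a 1.0-fold higher number from compound 1 to compound 3 (0.01 log units; within the scatter), a 1.3-fold higher number from compound 2 to compound 3 (0.10 log units; within the scatter) and a 1.3-fold lower number from compound 1 to compound 2 (0.10 log units; within the scatter), none of which moves beyond the scatter. Three different groups there left the number essentially unchanged, so no step beyond the scatter is expected in this assay for compound 4. Compound 4 is estimated at 650000 nM, with a range from 350000 nM to 1200000 nM. That estimate means an expected step of a 1.1-fold lower number from compound 3 to compound 4 (0.05 log units; within the scatter).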

Compound 4, half-maximal cytotoxic concentration: 568000 nM
The estimate for compound 4 lay 1.1-fold (0.06 log units) above the measured number; measured number inside the range.
By their numbers in this assay, from the lowest: compounds 4, 2, 1 and 3 (each within the scatter of the next).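

In this assay fluoro on this aromatic carbon, para to a large group, also stays within the scatter of every earlier compound (a 1.3-fold lower number from compound 3 to compound 4 (0.11 log units; within the scatter); a 1.0-fold lower number from compound 2 to compound 4 (0.01 log units; within the scatter); a 1.3-fold lower number from compound 1 to compound 4 (0.10 log units; within the scatter)). Hydrogen, methoxy, dimethylamino and fluoro thus give numbers that cannot be told apart here, although fluoro brings a single heavy atom in place of the three of dimethylamino. Nothing available explains why this position tolerates these exchanges so evenly. On these data alone, whether a carboxylic acid or a longer chain at this place would also stay within the scatter remains open. So does the effect of changes elsewhere on the shared core.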